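Saturating the side chain of compound 2

The source may hold more compounds than are shown below. What is called first, only, known or untested is meant among the compounds shown, and "the series" means these compounds.

Measured so far in a functional assay on WiDr cells (Homo sapiens) for antiproliferative activity, read by sulforhodamine B assay, with a stated time of 48 h; a higher number here means a weaker inhibitor of growth, a lower number a stronger inhibitor of growth:
compound 1 `CC(C)(C)[Si](C)(C)O[C@@H]1CCCO[C@@H]1COCC(=O)O`: > 100000 nM
compound 2 `CC(C)(C)[Si](C)(C)O[C@@H]1CCCO[C@@H]1CO/C=C/CO`: > 100000 nM

Both entries are limits of this assay, not numbers. Compound 2 stands at a limit, > 100000 nM, and no further reading places it more closely. For the measured compounds named here, the only measured step is a step that the two limits leave unreadable from compound 1 to compound 2, and the limit of > 100000 nM in this assay, at which 2 of the 2 values shown sit, is all that the series shows so far.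

Compound 3 `CC(C)(C)[Si](C)(C)O[C@@H]1CCCO[C@@H]1COCCCO` is the next compound to be read. It differs from compound 2 in one place: 3-hydroxypropyl in place of 3-hydroxyprop-1-en-1-yl on an oxygen on a saturated carbon. Going by the values given here, no measured step gives a size to carry over to this change, so no step beyond the scatter is expected in this assay, and another limit is the likeliest outcome. The estimated change is a number no higher from compound 2 to compound 3 (the limit leaves the size open). For compound 3 the expected value is 100000 nM, with an estimated range of 40000 nM to 200000 nM.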

Compound 3, concentration for 50% growth inhibition: > 100000 nM
Compound 3: a limit, no number; the forecaster's own chance of this, stated with the estimate: 85%; the middle value sits exactly at the limit.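

In this assay compound 3 gives > 100000 nM, a limit and not a number. The steps among compound 1, compound 2 and compound 3 therefore cannot be read. The compounds shown leave open how far their growth inhibition differs, and whether any side-chain change here would give a measurable value.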